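The source may report more compounds than this note shows. Statements on the series, on what has been measured and on what is new or still open speak of the compounds shown alone.

Measured compounds:
Compound 1, `CCc1ccc2[nH]c(=O)c(CN(Cc3ccc(C(C)(C)C)cc3)Cc3ccc(F)c(F)c3)cc2c1`: in a toxicity assay on MDCK cells (Canis lupus familiaris) for cytotoxicity, read by crystal violet staining, with a stated time of 48 h (on this read-out higher numbers stand for lower toxicity in this test and lower numbers for higher toxicity in this test), compound 1 gives > 33000 nM.
Compound 2, `Cc1ccc2[nH]c(=O)c(CN(Cc3ccc(OCC(=O)OC(C)(C)C)cc3)Cc3ccc(C(C)(C)C)cc3)cc2c1`: in this assay compound 2 gives > 10000 nM.

For compound 1 the result is a limit of the assay and not a number, namely (the limit of > 33000 nM in this assay, at which 1 of the 2 values shown sits). For compound 2 the result is likewise a limit, namely (the limit of > 10000 nM in this assay, at which 1 of the 2 values shown sits). Compound 1 therefore stands at a limit, and the one other value shown is a limit too, so nothing shown sets the two apart. Compound 3, `CCc1ccc2[nH]c(=O)c(CN(Cc3ccc(C(C)(C)C)cc3)[C@H](C)c3ccc(F)cc3)cc2c1`, has not yet been measured in this assay. It differs from compound 1 in a single place: 1-(4-fluorophenyl)ethyl in place of 3,4-difluorobenzyl on an amine nitrogen. Within the data shown here, no measured pair shows what such a change does here. Since both measured compounds reached only a limit, the step from compound 1 to compound 3 is expected to be a step that the limit leaves unreadable from compound 1 to compound 3, that is, none beyond the scatter. Compound 3 is estimated at 40000 nM, expected between 15000 nM and 100000 nM, most likely reported again only as a limit.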

Compound 3, half-maximal cytotoxic concentration: > 5000 nM
Compound 3 gave a limit, no number (the forecaster's own chance of this, stated with the estimate: 80%); the middle value is on the limit's open side.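

Compound 1 and compound 3 each gave only a limit in this assay, not a number, and the step between them cannot be read. It remains open whether 1-(4-fluorophenyl)ethyl in place of 3,4-difluorobenzyl changes the cytotoxicity at all, and at what concentration any compound shown would harm the cells.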